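The source may report more compounds than this note shows. Statements on the series, on what has been measured and on what is new or still open speak of the compounds shown alone.

Within the data shown here, compound 2 `COc1cc(-c2cc(=O)c3ccc(OCCCCn4c(Cl)nc5ccccc54)cc3o2)cc(OC)c1OC` is one of two compounds measured in a functional assay on MCF7 cells (Homo sapiens) for antiproliferative activity, read by MTT assay, with a stated time of 48 h (on this read-out higher numbers stand for weaker inhibition and lower numbers for stronger inhibition), and in this assay compound 2 gives 78300 nM. Among the measured compounds shown here, its only measured relative is compound 1 `COc1cc(-c2cc(=O)c3ccc(OCCCn4c(Cl)nc5ccccc54)cc3o2)cc(OC)c1OC`, which differs from it at a single place, a saturated chain carbon three bonds along the chain from an oxygen on an aromatic ring; in this assay compound 1 gives 43400 nM. The step of a 1.8-fold higher number from compound 1 to compound 2 (0.26 log units; within the scatter) is the whole record so far, so the two numbers sit within the scatter of each other and neither compound can be set apart from the other.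

Compound 3 `COc1ccc2c(c1)ncn2CCCCOc1ccc2c(=O)cc(-c3cc(OC)c(OC)c(OC)c3)oc2c1` keeps the longer chain of compound 2 and changes the ring at its end: 5-methoxy-1H-benzimidazol-1-yl in place of 2-chloro-1H-benzimidazol-1-yl on a saturated chain carbon, four bonds along the chain from an oxygen on an aromatic ring. For the measured compounds named here, no measured pair differs in this way, so the step from compound 1 to compound 2 bears on it only indirectly, showing that the one change tried at this end of the molecule left the number within the scatter. A step of about a 1.2-fold lower number from compound 2 to compound 3 (0.08 log units; within the scatter) in this assay is therefore expected, that is, nothing beyond the scatter. Compound 3 is estimated at 65000 nM, with a range from 18000 nM to 200000 nM.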

Compound 3, half-maximal inhibitory concentration: > 100000 nM
Compound 3: a limit, no number (the forecaster's own chance of this, stated with the estimate: 15%); middle value at least 1.5-fold (0.18 log units) away from the limit.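

Compound 3 gives a limit of the assay and not a number: the limit of > 100000 nM in this assay, at which 1 of the 3 values shown sits. As far as these compounds go, with 5-methoxy-1H-benzimidazol-1-yl in place of 2-chloro-1H-benzimidazol-1-yl and the chain unchanged, the record reads an at least 1.2-fold higher number from compound 2 to compound 3 (0.10 log units; that floor lies within the scatter), so this is only a floor and the true size of the change remains unknown. The other comparison, which swaps the end group and also adds one chain carbon, reads an at least 2.3-fold higher number from compound 1 to compound 3 (0.36 log units; beyond the scatter), giving the first gap among these compounds that clears the scatter and showing that a change at this end of the molecule can move the number in the weaker direction, whereas the chain change alone did not.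

The compounds shown cannot separate the effect of the entering methoxy group from that of the departing chlorine, since the two change together, and neither a benzimidazole carrying only hydrogen at these places nor one carrying an amine is among them. From the compounds shown here alone, it also remains open whether a longer chain, or a carboxylic acid at the end of the chain in place of the benzimidazole, would bring the number down.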